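This account rests on a few compounds, and the source may have more. Where it says the series, first, only, none or still open, it means among the compounds named here.

Measured compounds:
compound 1 `COc1ccc(C2=NN(C(=O)NS(=O)(=O)c3ccc(Cl)cc3)CC2C)c(OC)c1`: 18.8%
compound 2 `COc1ccc(C2=NN(C(=S)NC(=O)c3ccc(Cl)cc3)CC2C)c(OC)c1`: 1.43%

In a functional assay on the whole organism (strain albino) for inhibition, with Rattus norvegicus as the target, read by paw edema, with stated times of 30 min and 4 h, at a dose of 25 mg/kg by the intraperitoneal route (on this read-out lower numbers stand for less inhibition and higher numbers for more inhibition at the one dose given (going by the name of the read-out)), compound 1 gives 18.8%. In the same assay compound 2 gives 1.43%. For the measured compounds named here, of the two numbers known, compound 2 holds the lower one, and the gap to compound 1 is wider than the usual scatter of such measurements, so compound 1 does inhibit more than compound 2 at this dose.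

Compound 3 `COc1ccc(C2=NN(C(=S)NC(=O)c3ccc(Cl)cc3)CC2c2ccccc2)c(OC)c1` has not yet been measured. It is built from compound 2 by one change: phenyl in place of methyl on a saturated ring carbon. Going by the values given here, no pair of measured compounds shows the effect of this kind of change, so its size here is unknown. A modest move is expected, most likely upward but no larger than the scatter, giving an estimated step of a number 6.6 percentage points higher from compound 2 to compound 3 (within the scatter). On that basis compound 3 is expected to give 8%, with a likely range from 0% to 25%.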

Compound 3, a percentage reported as inhibition, in the whole organism at one dose (the size of the read-out at that dose, not a potency): 1.92%
Estimate against measurement, compound 3: 6.1 percentage points above; the measured number falls inside the stated range.
By their numbers in this assay, from the lowest: compounds 2 and 3 (each within the scatter of the next); then compound 1.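

In this assay, for the compounds shown here, putting phenyl in place of methyl on the saturated ring carbon comes with a number 0.5 percentage points higher from compound 2 to compound 3 (within the scatter), which is the first direct reading of this change. On the core shared by these two compounds, then, replacing a single carbon with a whole six-membered aromatic ring leaves the read-out unchanged within normal scatter, so this swap gives no sign that the position controls the effect at this dose. No measurement here bears on the reason for this result.

On these data alone, it remains open whether a different group on this carbon, such as an amine, a carboxylic acid or a longer chain, would shift the number. As far as these compounds go, it is also open whether the same swap from methyl to phenyl would behave alike on compound 1.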